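The source may report more compounds than this note shows. Statements on the series, on what has been measured and on what is new or still open speak of the compounds shown alone.

Values in an ADME assay on microsomes from liver (Homo sapiens) for metabolic stability; on this read-out lower numbers stand for a shorter-lived compound and higher numbers for a longer-lived compound:
Compound 1 `NS(=O)(=O)CC(=O)NCCSc1nonc1/C(=N/O)Nc1cccc(C(F)F)c1`: > 3 h, a limit.
Compound 2 `NS(=O)(=O)CC(=O)NCCSc1nonc1/C(=N/O)Nc1cccc(Cl)c1`: > 3 h, a limit.
Compound 3 `NS(=O)(=O)CC(=O)NCCSc1nonc1/C(=N/O)Nc1ccc(F)c(Br)c1`: 2.37 h.

Going by the values given here, compound 3 carries the only number, and the rest is the limit of > 3 h in this assay, at which 2 of the 3 values shown sit. Compound 4 `N#Cc1cccc(N/C(=N\O)c2nonc2SCCNC(=O)CS(N)(=O)=O)c1` is next, with 3-cyanophenyl in place of 3-bromo-4-fluorophenyl on an amine nitrogen. Two measured steps at this same place bear on it: an at least 1.2-fold lower number from compound 1 to compound 3 (0.10 log units; that floor lies within the scatter) and an at least 1.2-fold lower number from compound 2 to compound 3 (0.10 log units; that floor lies within the scatter). The remaining step, a step that the two limits leave unreadable from compound 1 to compound 2, gives no size. No step beyond the scatter is therefore expected in this assay, and the estimated change is a 1.3-fold higher number from compound 3 to compound 4 (0.10 log units; within the scatter). Compound 4 is expected at 3 h, with an estimated range of 1.6 h to 6 h.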

Compound 4, half-life: > 3 h
Compound 4: only a limit was reported; the forecaster's own chance of this, stated with the estimate: 50%; the middle value sits exactly at the limit.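

In this assay, 3-cyanophenyl in place of 3-bromo-4-fluorophenyl on an amine nitrogen gives an at least 1.2-fold higher number from compound 3 to compound 4 (0.10 log units; that floor lies within the scatter). The steps linking compound 4 to compound 1 and compound 2 join two limits and cannot be read. A nitrile now joins the difluoromethyl and chloro groups at this ceiling, which hides any ranking among these three compounds: the limit of > 3 h in this assay, at which 3 of the 4 values shown sit.

As far as these compounds go, whether any group at this place lowers the half-life beyond the scatter stays open. From the compounds shown here alone, how an amine or a carboxylic acid in place of the cyano group would read in this assay is also open.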